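The source may hold more compounds than are shown below. What is called first, only, known or untested is meant among the compounds shown, and "the series" means these compounds.

Measured compounds:
Compound 1, `CCCCCCCCOc1cc(-c2ccccc2)c(-c2ccccc2)nn1`, gives 104000 nM in an assay on microsomes from liver for inhibition of sterol O-acyltransferase 1 (Rattus norvegicus); a lower number here means a stronger inhibitor, a higher number a weaker inhibitor.
Compound 2, `CCCCCCCSc1cc(-c2ccccc2)c(-c2ccccc2)nn1`, gives 76000 nM in this assay.
Compound 3, `CCCCCC[S+]([O-])c1cc(-c2ccccc2)c(-c2ccccc2)nn1`, gives 75000 nM in this assay.

All three compounds share the same core and differ only in the chain on the aromatic carbon. Compound 3 sits among the three with a 1.4-fold lower number from compound 1 to compound 3 (0.14 log units; within the scatter) and a 1.0-fold lower number from compound 2 to compound 3 (0.01 log units; within the scatter), so its number cannot be told apart from either neighbour. Likewise a 1.4-fold lower number from compound 1 to compound 2 (0.14 log units; within the scatter) shows that swapping octyloxy for heptylsulfanyl leaves the number where it was.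

Compound 4, `CCCCCCS(=O)(=O)c1cc(-c2ccccc2)c(-c2ccccc2)nn1`, has not yet been tested. It differs from compound 3 by a group of 9 heavy atoms (6 carbon, 2 oxygen, 1 sulfur; no ring) in place of a group of 8 heavy atoms (6 carbon, 1 oxygen, 1 sulfur; no ring), on an aromatic carbon. Among the measured compounds shown here, the steps that bear on this change are those from compound 1 to compound 3 and from compound 2 to compound 3: both stayed within the scatter, and the whole series from ether through thioether to sulfoxide has been flat in this assay. On that basis the further change to the hexylsulfonyl is expected to give no step beyond the scatter, and the expected step from compound 3 to compound 4 is a 1.1-fold higher number from compound 3 to compound 4 (0.03 log units; within the scatter). Compound 4 is therefore estimated at 80000 nM in this assay, with a range from 30000 nM to 220000 nM.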

Compound 4, half-maximal inhibitory concentration: 60000 nM
For compound 4 the middle estimate is 1.3-fold (0.12 log units) above the measured one; measured number inside the range.
By their numbers in this assay, from the lowest: compounds 4, 3, 2 and 1 (each within the scatter of the next).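

In this assay the hexylsulfonyl group on this aromatic carbon adds one more chain to a flat series: the change from the chain of compound 3 gives a 1.3-fold lower number from compound 3 to compound 4 (0.10 log units; within the scatter) and stays inside the scatter. The comparison with the heptylsulfanyl chain gives a 1.3-fold lower number from compound 2 to compound 4 (0.10 log units; within the scatter) and the comparison with the octyloxy chain gives a 1.7-fold lower number from compound 1 to compound 4 (0.24 log units; within the scatter); this is the widest gap among the four compounds, yet it too is printed as within the scatter, so the ether, thioether, sulfoxide and sulfone forms of the linking atom cannot be told apart here. No measurement at hand offers an explanation for this flatness.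

As far as these compounds go, all four compounds carry a long open chain joined through oxygen or sulfur, so it remains open whether a much shorter chain, an amine or a carboxylic acid at this position would move the number beyond the scatter. Also open, from the compounds shown here alone, is whether putting a pyridyl group in place of either phenyl group would change the number, as both phenyl groups stay the same throughout.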